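The source may hold more compounds than are shown below. What is called first, only, known or untested is meant among the compounds shown, and "the series" means these compounds.

Measured so far in an ADME assay on THP-1 cells (Homo sapiens) for cytotoxicity, read by resazurin assay, with a stated time of 72 h; a lower number here means that less compound is tolerated, a higher number that more compound is tolerated:
compound 1 `CC(C)=CCOc1ccc(C(=O)/C=C/c2ccncc2)c(O)c1` gives 16000 nM
compound 2 `COc1cc(OCC=C(C)C)ccc1C(=O)/C=C/c1ccc(Br)cc1` gives 100000 nM

Of these two numbers, compound 2 stands highest; its nearest neighbour is compound 1, and that gap is beyond the usual scatter. Compound 3 `COc1cc(OCC=C(C)C)ccc1C(=O)/C=C/c1ccccc1` is the next compound to be measured in this assay. It differs from compound 2 in one place: hydrogen in place of bromo on an aromatic carbon. Among the measured compounds shown here, no measured pair shows this change, so its effect is unknown. The step from compound 2 to compound 3 is expected to be small, a 1.7-fold lower number from compound 2 to compound 3 (0.22 log units; within the scatter), most likely within the scatter. Compound 3 is therefore estimated at 60000 nM, with a range from 20000 nM to 150000 nM.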

Compound 3, half-maximal cytotoxic concentration: 50000 nM
For compound 3 the middle estimate is 1.2-fold (0.08 log units) above the measured one; low and high end bracket the measured number.
By their numbers in this assay, from the lowest: compound 1; then compounds 3 and 2 (each within the scatter of the next).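

Replacing 4-bromophenyl with phenyl gives a 2.0-fold lower number from compound 2 to compound 3 (0.30 log units; within the scatter) in this assay and so does not separate the two compounds. At this position, para to a large group, the bromo therefore shows no effect on tolerated concentration that stands clear of repeat measurements, though this rests on a single pair. Nothing at hand explains this result. From the compounds shown here alone, what an amine or a carboxylic acid would do on this aromatic carbon stays open. So does whether the same change would read alike on the core of compound 1.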